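The source may hold more compounds than are shown below. What is called first, only, known or untested is meant among the compounds shown, and "the series" means these compounds.

Among the compounds with values here, compound 1 `Cc1c(Cl)cccc1CCCCOc1ccc(C#Cc2cccc3c(CC(=O)O)c(C)n(CCCCC(=O)O)c23)cc1` stands at the weaker end of the two numbers so far: in a functional assay on HEK293 cells for antagonist activity at cysteinyl leukotriene receptor 2 (Homo sapiens), read by fluorescence and calcium flux, with stated times of 30 min and 1 h (on this read-out higher numbers stand for weaker inhibition and lower numbers for stronger inhibition), compound 1 gives 248 nM, whereas compound 2 `Cc1c(Cl)cccc1CCCCOc1ccc(C#Cc2cccc3c(CCC(=O)O)c(C)n(CCCCC(=O)O)c23)cc1` gives 60 nM, the one measured step being a 4.1-fold lower number from compound 1 to compound 2 (0.62 log units; beyond the scatter). Compound 3 `Cc1c(Cl)cccc1CCCCOc1ccc(C#Cc2cccc3c(CC(=O)O)c(C)n(CCCC(=O)O)c23)cc1` differs from compound 1 by carboxy in place of carboxymethyl on a saturated chain carbon, three bonds along the chain from an aromatic nitrogen. Within the data shown here, no measured step touches that chain; the step from compound 1 to compound 2 concerns the other acid chain and shows only that its length shifts the number beyond the scatter. For compound 3 a modest step toward a higher number, a 1.8-fold higher number from compound 1 to compound 3 (0.26 log units; within the scatter), is expected, the estimate being 450 nM with a range of 150 nM to 1400 nM.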

Compound 3, half-maximal inhibitory concentration in the cysteinyl leukotriene receptor 2 assay: 55 nM
Estimate against measurement, compound 3: 8.2-fold (0.91 log units) above, and the stated range ends above it.
By their numbers in the cysteinyl leukotriene receptor 2 assay, from the lowest: compounds 3 and 2 (each within the scatter of the next); then compound 1.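

In the cysteinyl leukotriene receptor 2 assay, 3-carboxypropyl in place of 4-carboxybutyl gives a 4.5-fold lower number from compound 1 to compound 3 (0.65 log units; beyond the scatter), so this acid chain, like the one changed in the earlier step, moves the number beyond the scatter, here toward stronger inhibition. The same change also registers in a physicochemical assay for permeability, using PAMPA, with a stated time of 4 h, at pH 7.4, tested at 50 uM (a lower number here means that the compound crosses the layer more slowly, a higher number that the compound crosses the layer faster), where compound 1 gives 1 10^-6 cm/s and compound 3 gives 4.4 10^-6 cm/s: the measured apparent permeability of compound 1, 1 10^-6 cm/s, and of compound 3, 4.4 10^-6 cm/s, a 4.4-fold higher number (0.64 log units; beyond the scatter)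

Open, on these data alone, is whether a shorter 2-carboxyethyl chain at this place, or a primary amide or tetrazole in place of its carboxylic acid, would hold the stronger inhibition. Also open, as far as these compounds go, is how the shortenings of the two acid chains behave when combined in one compound.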